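The source may report more compounds than this note shows. Statements on the series, on what has been measured and on what is new or still open speak of the compounds shown alone.

In an ADME assay on cells (Hepatocyte, Mus musculus) for metabolic stability, with a stated time of 30 min (a higher number here means that more of the compound is left, a lower number that less of the compound is left), compound 2 `O=C(OC1CCC(CN2CCN(c3cc(=O)c4cc(C(F)(F)F)cc([N+](=O)[O-])c4s3)CC2)CC1)c1ccncc1` stands lowest of the two numbers, with 1.4%. Among the measured compounds shown here, compound 1 `NC1CCC(CN2CCN(c3cc(=O)c4cc(C(F)(F)F)cc([N+](=O)[O-])c4s3)CC2)CC1` gives 107%, and the single measured step, a number 105.6 percentage points lower from compound 1 to compound 2 (beyond the scatter), is large but touches a different part of the molecule. Compound 3 `O=C(OC1CCC(CN2CCN(c3cc(=O)c4cc(C(F)(F)F)cc([N+](=O)[O-])c4s3)CC2)CC1)c1ccc(C(F)(F)F)cc1` differs from compound 2 by 4-(trifluoromethyl)phenyl in place of pyridin-4-yl on a carbonyl carbon. For the measured compounds named here, no measured step bears directly on this change. Because compound 2 sits at 1.4%, there is little room for a further fall, so a step no larger than the scatter, a number 1.6 percentage points higher from compound 2 to compound 3 (within the scatter), is expected. Compound 3 is estimated at 3%, within 0% to 15%.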

Compound 3, percent of the compound remaining: 28.8%
Compound 3: middle estimate off by 25.8 percentage points, on the low side, outside the stated range (above it).
By their numbers in this assay, from the lowest: compound 2; then compound 3; then compound 1.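

The group on the carbonyl carbon turns out to matter in this assay: putting 4-(trifluoromethyl)phenyl in place of pyridin-4-yl gives a number 27.4 percentage points higher from compound 2 to compound 3 (beyond the scatter) and so lifts the number clear of the floor that compound 2 sits near. The earlier step changed a different part of the molecule and could not show this. Nothing available explains why this change has this effect.

The compounds shown do not separate the effect of adding trifluoromethyl from that of losing the ring nitrogen, which a plain phenyl on the carbonyl carbon could do. From the compounds shown here alone, how an amide in place of the ester would behave also stays open.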